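This account rests on a few compounds, and the source may have more. Where it says the series, first, only, none or still open, it means among the compounds named here.

The measured compounds:
Compound 1, `C/C=C/Cn1cc(-c2ccc(C(=O)N3CCN(S(C)(=O)=O)CC3)c(Cl)c2)n2cncc2c1=O`, gives 2290 nM in a functional assay on EOL1 cells (Homo sapiens) for antiproliferative activity; on this read-out higher numbers stand for weaker inhibition and lower numbers for stronger inhibition.
Compound 2, `C/C=C/Cn1cc(-c2ccc(C(=O)N3CCC(C(N)=O)CC3)c(Cl)c2)n2cncc2c1=O`, gives 3420 nM in this assay.
Compound 3, `C/C=C/Cn1cc(-c2ccc(C(=O)NC3CCS(=O)(=O)CC3)c(Cl)c2)n2cncc2c1=O`, gives 5340 nM in this assay.

Compound 3 stands with the highest of the three numbers. Its nearest neighbour is compound 2, with a 1.6-fold higher number from compound 2 to compound 3 (0.19 log units; within the scatter), and the gap to compound 1 is larger, a 2.3-fold higher number from compound 1 to compound 3 (0.37 log units; beyond the scatter). Compound 4, `C/C=C/Cn1cc(-c2ccc(C(=O)N3CCCC3)c(Cl)c2)n2cncc2c1=O`, differs from compound 3 at the carbonyl carbon only: pyrrolidin-1-yl in place of (1,1-dioxothian-4-yl)amino on a carbonyl carbon. All three measured steps bear on this position, since each exchanges the group on the same carbonyl carbon: a 1.5-fold higher number from compound 1 to compound 2 (0.17 log units; within the scatter), a 2.3-fold higher number from compound 1 to compound 3 (0.37 log units; beyond the scatter) and a 1.6-fold higher number from compound 2 to compound 3 (0.19 log units; within the scatter). Among the compounds with values here, none of them is large, and no measured pair covers a group like pyrrolidin-1-yl, so the direction of the change is uncertain. The step is expected to be small and to move the number back toward the middle of the range spanned by compounds 1 to 3: a 1.5-fold lower number from compound 3 to compound 4 (0.18 log units; within the scatter). Compound 4 is therefore expected to give 3500 nM, with a range from 1500 nM to 9000 nM.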

Compound 4, half-maximal inhibitory concentration: 5820 nM
Beside the measured number, compound 4's estimate is 1.7-fold (0.22 log units) below it, within the range that was stated.
By their numbers in this assay, from the lowest: compounds 1, 2, 3 and 4 (each within the scatter of the next, the first and the last beyond it).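

Exchanging the (1,1-dioxothian-4-yl)amino group for pyrrolidin-1-yl, which has no hydrogen-bond donors or acceptors, gives a 1.1-fold higher number from compound 3 to compound 4 (0.04 log units; within the scatter) in this assay, and exchanging 4-carbamoylpiperidin-1-yl for it gives a 1.7-fold higher number from compound 2 to compound 4 (0.23 log units; within the scatter). Only the exchange of 4-(methylsulfonyl)piperazin-1-yl for pyrrolidin-1-yl passes beyond the scatter, with a 2.5-fold higher number from compound 1 to compound 4 (0.41 log units; beyond the scatter), so among these four compounds a simple ring on the carbonyl carbon matches compounds 2 and 3 and only compound 1 stands apart from it. Nothing available here accounts for these steps.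

On these data alone, it remains open whether an open-chain amine such as dimethylamino, or a piperidine bearing a carboxylic acid, would fall with compound 1 or with compound 4. As far as these compounds go, it also remains open whether a morpholine on the same carbonyl carbon would match compound 1.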